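Adding a Nitro Group to a Bromo-Dimethoxy Inhibitor

The source may hold more compounds than are shown below. What is called first, only, known or untested is meant among the compounds shown, and "the series" means these compounds.

Of the compounds shown here, two have been measured so far. Compound 1 `COc1cc(Br)c(-c2nc3ccccc3[nH]2)cc1OC` and compound 2 `Oc1c(Br)cc(Cl)cc1-c1nc2ccccc2[nH]1` share one core. In an assay for inhibition of Alpha amylase (Homo sapiens), with a stated time of 10 min (on this read-out lower numbers stand for stronger inhibition and higher numbers for weaker inhibition), compound 1 gives 1510 nM. In this assay compound 2 gives 2850 nM; these two numbers lie within the scatter of each other, so neither stands apart. Compound 3 `COc1cc(Br)c(-c2nc3cc([N+](=O)[O-])ccc3[nH]2)cc1OC` differs from compound 1 by nitro in place of hydrogen on an aromatic carbon. Going by the values given here, no measured pair shows what such a change does here, so the step of a 1.3-fold lower number from compound 1 to compound 3 (0.10 log units; within the scatter) is expected to be small, not beyond the scatter. Compound 3 is therefore estimated at 1200 nM, within 400 nM to 4000 nM.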

Compound 3, half-maximal inhibitory concentration: 1870 nM
For compound 3 the middle estimate is 1.6-fold (0.19 log units) below the measured one; the range from low to high includes it.
By their numbers in this assay, from the lowest: compounds 1, 3 and 2 (each within the scatter of the next).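

The first step measured at this aromatic carbon of the shared core is a 1.2-fold higher number from compound 1 to compound 3 (0.09 log units; within the scatter), so in this assay compound 1 and compound 3 cannot be told apart. This position can therefore carry nitro, with its three heavy atoms, and still give a number in the same range as the compound bearing hydrogen there. Nothing available here bears on why this is so.

Going by these compounds, whether an amine or a carboxylic acid on this same carbon would give a number beyond the scatter remains open. So does whether nitro would give a similar result on compound 2.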